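This account rests on a few compounds, and the source may have more. Where it says the series, first, only, none or still open, it means among the compounds named here.

Measured compounds:
Compound 1, `C=C1C[C@]23C[C@@]1(O)CC[C@H]2c1cc(Br)c(O)c(C)c1[C@@H]3Cn1cc(-c2ccc(OC)cc2)nn1`: in a functional assay on SW480 cells (Homo sapiens) for cytotoxicity, read by MTT assay, with a stated time of 4 days (on this read-out higher numbers stand for weaker inhibition and lower numbers for stronger inhibition), compound 1 gives > 20000 nM, which is a limit of the assay rather than a number.
Compound 2, `C=C1C[C@]23C[C@@]1(O)CC[C@@H]2c1cccc(C)c1[C@@H]3Cn1cc(-c2ccc(Br)cc2)nn1`: in this assay compound 2 gives > 20000 nM, again a limit of the assay.

Within the data shown here, both measured compounds therefore sit at the same limit (the limit of > 20000 nM in this assay, at which 2 of the 2 values shown sit), and compound 2 stands there alongside the only other value shown. Among the measured compounds shown here, no step between measured compounds can be read from these numbers; the two limits show only that neither compound reached a measurable inhibitory concentration within the tested range.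

Compound 3, `C=C1C[C@]23C[C@@]1(O)CC[C@@H]2c1cccc(C)c1[C@@H]3Cn1cc(-c2ccc(C(F)(F)F)cc2)nn1`, differs from compound 2 in one place: trifluoromethyl in place of bromo on an aromatic carbon. For the measured compounds named here, with no measured step to lean on, the expectation rests on where compound 2 stands, a limit with no number behind it. The step expected in this assay is a step that the limit leaves unreadable from compound 2 to compound 3, which is none beyond the usual scatter. Compound 3 is therefore expected to give about 25000 nM, with a likely range from 8000 nM to 80000 nM, and most probably the assay will again report only a limit.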

Compound 3, half-maximal inhibitory concentration: > 20000 nM
Compound 3 ended at the assay's limit (the forecaster's own chance of this, stated with the estimate: 75%); the middle value does not contradict the limit.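

Compound 3, like compound 2, gives only a limit of the assay and not a number, so no step can be read from the swap of bromo for trifluoromethyl: the limit of > 20000 nM in this assay, at which 3 of the 3 values shown sit. The compounds shown leave open how strongly any of them acts in this assay, and whether any change to the shared core would give a measurable value.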